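The compounds below may be only part of what the source reports. "The series", "measured", "known", "first", "only" and "open" are said of these compounds alone.

Measured in a functional assay on the whole organism for inhibition, with Canis familiaris (Canis lupus familiaris) as the target; on this read-out higher numbers stand for an effect only at larger amounts of compound and lower numbers for an effect already at smaller amounts:
compound 1 `CCN1CCCC1CNC(=O)c1cc(NS(=O)(=O)N(C)C)c(Cl)cc1OC`: 0.05 mg/kg
compound 2 `CCN1CCCC1CNC(=O)c1cc(NS(N)(=O)=O)ccc1OC`: 10 mg/kg

Compound 2 stands at the highest of the two numbers in this assay, and the gap to compound 1 is far beyond the scatter. Going by the values given here, compound 1 and compound 2 differ in two places at once, the ring chloro and the methylation of the sulfamoyl nitrogen, so no single step between measured compounds is isolated.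

Compound 3 `CCN1CCCC1CNC(=O)c1cc(NS(N)(=O)=O)c(Cl)cc1OC` differs from compound 2 by chloro in place of hydrogen on an aromatic carbon. It thus carries the ring substitution of compound 1 while keeping the unmethylated sulfamoyl group of compound 2. As far as these compounds go, a step downward, beyond the scatter, is expected from compound 2 to compound 3, but how much of the gap to compound 1 the chloro alone accounts for is unknown, since the methylation remains untested. The estimate for compound 3 is 1 mg/kg, in the range 0.1 mg/kg to 10 mg/kg, corresponding to an expected step of a 10-fold lower number from compound 2 to compound 3 (1.00 log units; beyond the scatter).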

Compound 3, dose for half-maximal effect: 1 mg/kg
Estimate against measurement, compound 3: no gap at the digits printed; the measured number falls inside the stated range.
By their numbers in this assay, from the lowest: compound 1; then compound 3; then compound 2.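

In this assay, chloro in place of hydrogen on the aromatic carbon ortho to a sulfamoylamino group gives a 10-fold lower number from compound 2 to compound 3 (1.00 log units; beyond the scatter), so this position alone moves the dose beyond the scatter. With the chloro held constant, amino in place of dimethylamino on the sulfonyl sulfur gives a 20-fold higher number from compound 1 to compound 3 (1.30 log units; beyond the scatter), so the change at the sulfur also moves the dose beyond the scatter and the chloro step does not account for the whole distance between compound 1 and compound 2. Nothing available explains either step.

The compounds shown leave open whether the step at the sulfur keeps its size with hydrogen in place of the chloro. They also leave open how bromo or methyl on that aromatic carbon, or diethylamino on the sulfonyl sulfur, would compare.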